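Amide-to-sulfonyl swap on a chromone aryl scaffold

The source may hold more compounds than are shown below. What is called first, only, known or untested is meant among the compounds shown, and "the series" means these compounds.

Compound 1 `Cc1ccc(C(=O)Nc2cccc(NC(=O)COc3ccc4c(=O)ccoc4c3)c2)cc1`: 183 nM
Compound 2 `CCOc1ccc(C(=O)Nc2cccc(NC(=O)COc3ccc4c(=O)ccoc4c3)c2)cc1`: 17 nM
Compound 3 `CC(C)(C)c1cc(C(=O)Nc2cccc(NC(=O)COc3ccc4c(=O)ccoc4c3)c2)no1`: 101 nM

In an assay on isolated protein for inhibition of Rho-associated protein kinase 1 (Homo sapiens), read by scintillation counting, radiometric assay and 33P incorporation, with a stated time of 40 min, in the presence of a further agent that is not named here (a higher number here means a weaker inhibitor, a lower number a stronger inhibitor), compound 3 gives 101 nM, the second highest number of the three measured compounds. Its nearest neighbour is compound 1, and the step of a 1.8-fold lower number from compound 1 to compound 3 (0.26 log units; within the scatter) stays within the scatter. The step of a 5.9-fold higher number from compound 2 to compound 3 (0.77 log units; beyond the scatter) is the only one beyond the scatter that bears on compound 3, and it shows how far the group on the carbonyl carbon can move the number within this series.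

Compound 4 `Cn1ccc(S(=O)(=O)Nc2cccc(NC(=O)COc3ccc4c(=O)ccoc4c3)c2)n1` carries a new group at that position: a group of 9 heavy atoms (4 carbon, 2 nitrogen, 2 oxygen, 1 sulfur; one five-membered aromatic ring with 2 hetero atoms) in place of a group of 11 heavy atoms (8 carbon, 1 nitrogen, 2 oxygen; one five-membered aromatic ring with 2 hetero atoms), on a nitrogen on an aromatic ring. Among the measured compounds shown here, none of the measured steps swaps a carbonyl for the entering group, so no step speaks to this change directly. The steps that vary the acyl group, a 1.8-fold lower number from compound 1 to compound 3 (0.26 log units; within the scatter) and a 5.9-fold higher number from compound 2 to compound 3 (0.77 log units; beyond the scatter), range from within the scatter to modest, and the three measured numbers span a modest window. The expected step is therefore a 1.5-fold higher number from compound 3 to compound 4 (0.17 log units; within the scatter), with no direction that the data can support. Compound 4 is estimated at 150 nM in this assay, between 35 nM and 650 nM.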

Compound 4, half-maximal inhibitory concentration: > 10000 nM
Compound 4: no number, only a limit; the forecaster's own chance of this, stated with the estimate: 10%; middle value at least 66-fold (1.82 log units) from the limit.
By their numbers in this assay, from the lowest: compound 2; then compounds 3 and 1 (each within the scatter of the next). At a limit, above all of these: compound 4.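

In this assay, compound 4 gives a limit of the assay and not a number: the limit of > 10000 nM in this assay, at which 1 of the 4 values shown sits. Every step into compound 4 is large: an at least 99-fold higher number from compound 3 to compound 4 (1.99 log units; beyond the scatter), an at least 580-fold higher number from compound 2 to compound 4 (2.76 log units; beyond the scatter) and an at least 54-fold higher number from compound 1 to compound 4 (1.73 log units; beyond the scatter). Among the compounds shown here, each of these exceeds the widest step among the carbonyl-linked compounds, an 11-fold lower number from compound 1 to compound 2 (1.03 log units; beyond the scatter), so the nitrogen on an aromatic ring is a place where the change of group can move the number much further than the earlier compounds showed, and a five-membered aromatic ring with 2 hetero atoms, present in both compound 3 and compound 4, does not by itself keep the number in the range of compound 3.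

The compounds shown leave open whether this step goes with the sulfonyl link or with the group it carries, as the entering group differs from each leaving group in both, and a 4-ethoxyphenyl on a sulfonyl or the ring of compound 4 on a carbonyl would separate the two. They also leave open how a urea link or a plain methylsulfonyl group would read at this nitrogen.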